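Methyl to ethyl: from compound 2 to compound 3

This account rests on a few compounds, and the source may have more. Where it says the series, first, only, none or still open, it means among the compounds named here.

In a functional assay on NCI-H1975 cells (Homo sapiens) for inhibition, read by MTT assay, with a stated time of 72 h (on this read-out higher numbers stand for weaker inhibition and lower numbers for stronger inhibition), compound 1 `FC(F)(F)c1ccc(CSc2nc(N3CCNCC3)cc(C(F)(F)F)n2)cc1` gives 6210 nM and compound 2 `CN1CCN(c2cc(C(F)(F)F)nc(SCc3ccc(C(F)(F)F)cc3)n2)CC1` gives 23900 nM. Compound 2 therefore holds the higher number of the two measured compounds and shows the weaker inhibition. Compound 3 `CCN1CCN(c2cc(C(F)(F)F)nc(SCc3ccc(C(F)(F)F)cc3)n2)CC1` differs from compound 2 by one change: methyl in place of hydrogen on a saturated chain carbon bound to an amine nitrogen in a ring. This is methyl in place of hydrogen on a saturated chain carbon bound to an amine nitrogen in a ring, turning methyl into ethyl. Within the data shown here, only one measured step bears on it: a 3.8-fold higher number from compound 1 to compound 2 (0.59 log units; beyond the scatter), a modest step for methyl in place of hydrogen on an amine nitrogen in a ring. That step falls on the nitrogen itself, not on the carbon bound to it, and a single step sets no trend. No shift beyond the scatter is expected, and the expected step is a 1.0-fold higher number from compound 2 to compound 3 (0.00 log units; within the scatter). For compound 3 the estimated value is 24000 nM, within an expected range of 11000 nM to 50000 nM.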

Compound 3, half-maximal inhibitory concentration: 15000 nM
For compound 3 the middle estimate is 1.6-fold (0.20 log units) above the measured one; the measured number falls inside the stated range.
By their numbers in this assay, from the lowest: compound 1; then compounds 3 and 2 (each within the scatter of the next).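

In this assay, methyl in place of hydrogen on a saturated chain carbon bound to an amine nitrogen in a ring, turning 4-methylpiperazin-1-yl into 4-ethylpiperazin-1-yl, gives a 1.6-fold lower number from compound 2 to compound 3 (0.20 log units; within the scatter), so this change does not separate the two compounds on this read-out. Replacing hydrogen with ethyl on that nitrogen gives a 2.4-fold higher number from compound 1 to compound 3 (0.38 log units; beyond the scatter), so ethyl, like methyl, stands apart from hydrogen on this nitrogen, while the two groups do not stand apart from each other. No supporting measurement bears on why the numbers fall this way.

Going by these compounds, whether a longer chain such as propyl or a branched chain such as isopropyl on this nitrogen would stay with compound 2 and compound 3 or move toward compound 1 remains open. The same question holds for a hydroxyethyl chain or an acetyl group there.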